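The compounds below may be only part of what the source reports. "The series", "measured", "known", "first", "only" and "open" are said of these compounds alone.

Measured so far:
Compound 1 `COc1ccc(C(Nc2cc(C)ccn2)c2ccc3cccnc3c2O)cc1O` — 150 nM
Compound 2 `Cc1ccnc(NC(c2ccccc2)c2ccc3cccnc3c2O)c1` — < 200 nM, a limit of the assay
Compound 3 `CCc1ccc(C(Nc2cc(C)ccn2)c2ccc3cccnc3c2O)cc1` — 5390 nM

In an assay for inhibition of protein disulfide-isomerase (Homo sapiens), with a stated time of 1 h (a lower number here means a stronger inhibitor, a higher number a weaker inhibitor), compound 3 gives 5390 nM, the highest of the two numbers shown. Compound 1 gives 150 nM, and the step of a 36-fold higher number from compound 1 to compound 3 (1.56 log units; beyond the scatter) is large. Compound 2 shows only a limit of the assay, < 200 nM. Against that limit, an at least 26-fold higher number from compound 2 to compound 3 (1.43 log units; beyond the scatter) is also large. The step that the limit leaves unreadable from compound 1 to compound 2 cannot be sized because the limit of < 200 nM in this assay, at which 1 of the 3 values shown sits, hides it.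

Compound 4 `Cc1ccnc(NC(c2cc(C)ccc2C)c2ccc3cccnc3c2O)c1` is not yet measured. It differs from compound 3 by 2,5-dimethylphenyl in place of 4-ethylphenyl on a saturated chain carbon bound to an aromatic carbon and a nitrogen on an aromatic ring; the two have the same atoms joined differently. Both measured steps that end at compound 3 change the group at this same place and are large, but compound 4 keeps a phenyl carrying only alkyl groups, as compound 3 does. A modest step toward a lower number is therefore expected, a 2.2-fold lower number from compound 3 to compound 4 (0.33 log units; beyond the scatter). Compound 4 is estimated at 2500 nM, in the range 800 nM to 8000 nM.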

Compound 4, half-maximal inhibitory concentration: > 40000 nM
Compound 4: a limit, no number; the forecaster's own chance of this, stated with the estimate: 5%; middle value at least 16-fold (1.20 log units) from the limit.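

In this assay compound 4 gives > 40000 nM, which is a limit of the assay and not a number. For the compounds shown here, with the same 8 carbon atoms in both groups, 2,5-dimethylphenyl in place of 4-ethylphenyl still gives an at least 7.4-fold higher number from compound 3 to compound 4 (0.87 log units; beyond the scatter), so at this place the arrangement of alkyl carbons on the phenyl changes the result, which the earlier steps, all of which also changed the group's substitution type or size, could not show. The steps of an at least 200-fold higher number from compound 2 to compound 4 (2.30 log units; beyond the scatter) and an at least 260-fold higher number from compound 1 to compound 4 (2.42 log units; beyond the scatter) are larger than any step seen earlier at this place.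

Which methyl of the 2,5-dimethylphenyl carries the change stays open, as a phenyl with one methyl group is not among the compounds shown. Going by these compounds, whether an amine on the phenyl would return the number toward that of compound 1 also stays open.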